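One Methyl Fewer on the Five-Membered Ring

A few compounds are considered here, and "the series" means these few. Any claim that something is new, unique, unknown or untested is made for them only; others in the source may bear on it.

Among the compounds with values here, compound 2 `CC(C(=O)N1CCN(c2cccc(C(F)(F)F)c2)CC1)N1C(=O)CC(C)(C)C1=O` gives 29 mg/kg in a functional assay on the whole organism (strain Swiss) with Mus musculus as the target, with a stated time of 0.25 h (a lower number here means that less compound is needed, a higher number that more compound is needed for the effect), the higher of the two numbers measured so far, while compound 1 `CC1CC(=O)N(C(C)C(=O)N2CCN(c3cccc(Cl)c3)CC2)C1=O` gives 13.6 mg/kg in this assay, a gap beyond the usual scatter. Compound 3 `CC1CC(=O)N(C(C)C(=O)N2CCN(c3cccc(C(F)(F)F)c3)CC2)C1=O` is still unmeasured. It differs from compound 2 by hydrogen in place of methyl on a saturated ring carbon. Within the data shown here, no measured pair isolates this change, so the direction is uncertain; a small shift toward a lower number is expected, a 1.5-fold lower number from compound 2 to compound 3 (0.16 log units; within the scatter), possibly within the scatter. Compound 3 is therefore estimated at 20 mg/kg, ranging from 9 mg/kg to 45 mg/kg.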

Compound 3, dose for half-maximal effect: 24.6 mg/kg
Beside the measured number, compound 3's estimate is 1.2-fold (0.09 log units) below it; measured number inside the range.
By their numbers in this assay, from the lowest: compounds 1, 3 and 2 (each within the scatter of the next, the first and the last beyond it).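

In this assay the change from 3,3-dimethyl-2,5-dioxopyrrolidin-1-yl to 3-methyl-2,5-dioxopyrrolidin-1-yl gives a 1.2-fold lower number from compound 2 to compound 3 (0.07 log units; within the scatter) and so shows that this saturated ring carbon can lose one methyl without a clear shift. Compound 3 also isolates the aromatic change, where trifluoromethyl in place of chloro gives a 1.8-fold higher number from compound 1 to compound 3 (0.26 log units; within the scatter) and likewise stays within the scatter. Only compound 1 and compound 2, which differ in both places, lie beyond it. Nothing available explains these small steps. As far as these compounds go, whether this ring carbon would accept an ethyl or a hydroxyl group stays open.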